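The compounds below may be only part of what the source reports. "The series", "measured", "known", "first", "only" and "open" are said of these compounds alone.

Series notes. In a functional assay on MCF7 cells (Homo sapiens) for antiproliferative activity, read by MTT assay, with a stated time of 72 h (a lower number here means a stronger inhibitor, a higher number a weaker inhibitor), compound 1 (`O=C(COc1ccc(C(=O)/C=C/c2cccc(Cl)c2)cc1)N[C@H]1CCOC1=O`) gives 20900 nM. Compound 2 (`O=C(CNc1ccccc1F)N[C@H]1CCOC1=O`) returns only a limit of the assay in this assay, reported as > 64000 nM. Compound 3 (`CCOc1ccccc1OCCSC(=S)N[C@H]1CCOC1=O`) likewise returns only a limit in this assay, namely > 64000 nM. Compound 2 therefore sits at the limit of > 64000 nM in this assay, at which 2 of the 3 values shown sit, with no number of its own. Compound 4 (`O=C(CNc1ccccc1)N[C@H]1CCOC1=O`) differs from compound 2 by hydrogen in place of fluoro on an aromatic carbon. For the measured compounds named here, no measured step of this kind exists. The step is expected to be a step that the limit leaves unreadable from compound 2 to compound 4, with no movement beyond the scatter and the reading expected to remain at the limit. Compound 4 is expected to give 70000 nM, within 30000 nM to 150000 nM.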

Compound 4, half-maximal inhibitory concentration: > 64000 nM
Compound 4: only a limit was reported; the forecaster's own chance of this, stated with the estimate: 75%; the middle value is on the limit's open side.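

Compound 2 and compound 4 both return only a limit of the assay in this assay, so no new step can be read between them. The compounds shown leave open whether hydrogen in place of fluoro on an aromatic carbon changes the reading in this assay at all.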